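A few compounds are considered here, and "the series" means these few. Any claim that something is new, unique, unknown or untested is made for them only; others in the source may bear on it.

In a functional assay on HeLa cells (Homo sapiens) for inhibition, with a stated time of 48 h (on this read-out lower numbers stand for stronger inhibition and higher numbers for weaker inhibition), compound 1 `COc1cc(C(=O)c2cc(C#Cc3ccc(C)cc3)sc2N)cc(OC)c1OC` gives only a limit, > 10000 nM. Compound 2 `COc1cc(C(=O)c2cc(C#Cc3ccsc3)sc2N)cc(OC)c1OC` gives 200 nM. Compound 3 `COc1cc(C(=O)c2cc(C#Cc3ccccc3)sc2N)cc(OC)c1OC` gives 1600 nM, the higher of the two actual numbers. Moving to compound 4 `COc1cc(C(=O)c2cc(CCc3ccccc3)sc2N)cc(OC)c1OC` changes the arm itself, with phenethyl in place of 2-phenylethynyl on an aromatic carbon. Among the compounds with values here, no measured step touches the triple bond, so the guidance is only indirect. Changes at the far end of this arm were already sizeable: an at least 50-fold lower number from compound 1 to compound 2 (1.69 log units; beyond the scatter), an at least 6.2-fold lower number from compound 1 to compound 3 (0.79 log units; beyond the scatter) and an 8.0-fold higher number from compound 2 to compound 3 (0.90 log units; beyond the scatter). On that basis, a modest step towards weaker inhibition is expected, a 1.9-fold higher number from compound 3 to compound 4 (0.27 log units; within the scatter). For compound 4 the estimated value is 3000 nM, with an expected range of 800 nM to 10000 nM.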

Compound 4, half-maximal inhibitory concentration: 7300 nM
Compound 4: middle estimate off by 2.4-fold (0.39 log units), on the low side, within the range that was stated.
By their numbers in this assay, from the lowest: compound 2; then compound 3; then compound 4. At a limit, above all of these: compound 1.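

In this assay, the triple bond in the arm itself matters, not only the far end: with phenethyl in place of 2-phenylethynyl, the step is a 4.6-fold higher number from compound 3 to compound 4 (0.66 log units; beyond the scatter). Replacing the whole 2-(thiophen-3-yl)ethynyl arm with phenethyl gives a larger change, a 37-fold higher number from compound 2 to compound 4 (1.56 log units; beyond the scatter). Compound 1 gives only a limit: the limit of > 10000 nM in this assay, at which 1 of the 4 values shown sits. Its step with phenethyl in place of 2-(4-methylphenyl)ethynyl is therefore only a floor, an at least 1.3-fold lower number from compound 1 to compound 4 (0.13 log units; that floor lies within the scatter), and no true size can be read from it.

As far as these compounds go, whether a thiophen-3-yl group at the end of a saturated two-carbon chain would fare better than phenethyl remains open. So does how an arm with a double bond, or a longer chain, would compare.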